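Piperidinyl to dimethylamino exchange on two related cores

This account rests on a few compounds, and the source may have more. Where it says the series, first, only, none or still open, it means among the compounds named here.

Compound 1 `COc1ccc2[nH]c([S+]([O-])Cc3ncc(C)c(N4CCCCC4)c3Cl)nc2c1` gives 2.38 umol/kg in a functional assay on the whole organism (stomach) for inhibition, with Rattus norvegicus as the target; a higher number here means that more compound is needed for the effect, a lower number that less compound is needed. Compound 2 `COc1ccc2[nH]c([S+]([O-])Cc3ncc(C)c(N(C)C)c3Cl)nc2c1` gives 0.34 umol/kg in this assay; the step of a 7.0-fold lower number from compound 1 to compound 2 (0.85 log units; beyond the scatter) accompanies the change (dimethylamino in place of piperidin-1-yl on an aromatic carbon). Compound 3 `COc1ccc2[nH]c([S+]([O-])Cc3cc(N4CCCCC4)c(Br)cn3)nc2c1` gives 0.85 umol/kg in this assay; the difference between the cores of compound 1 and compound 3 is not broken down here. Compound 4 `COc1ccc2[nH]c([S+]([O-])Cc3cc(N(C)C)c(Br)cn3)nc2c1` is not yet measured and differs from compound 3 by dimethylamino in place of piperidin-1-yl on an aromatic carbon. This is the same kind of change as that from compound 1 to compound 2, not the same: there the group sat ortho to a chloro group and ortho to a methyl group, here it sits ortho to a bromo group; in both it is meta to a large group and opposite the ring nitrogen. For compound 4, a 4.3-fold lower number from compound 3 to compound 4 (0.63 log units; beyond the scatter) is expected, resting on a 7.0-fold lower number from compound 1 to compound 2 (0.85 log units; beyond the scatter). The surroundings differ, so the assumed step is kept smaller than the earlier one. Compound 4 is estimated at 0.2 umol/kg, expected between 0.08 umol/kg and 0.5 umol/kg.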

Compound 4, dose for half-maximal effect: 0.26 umol/kg
Beside the measured number, compound 4's estimate is 1.3-fold (0.11 log units) below it; the range from low to high includes it.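

In this assay, the exchange of piperidin-1-yl for dimethylamino carries over to the second core, giving a 3.3-fold lower number from compound 3 to compound 4 (0.51 log units; beyond the scatter). The number falls on both cores, and the two steps do not differ in size beyond the scatter: the same change on two cores in this assay, a 7.0-fold lower number (0.85 log units; beyond the scatter) from compound 1 to compound 2 and a 3.3-fold lower number (0.51 log units; beyond the scatter) from compound 3 to compound 4, 2.1-fold (0.33 log units) apart, within the scatter of two such steps. Among the compounds shown here, this rests on only two pairs in this assay, so it does not establish that the step would hold on further cores, and it does not explain why the number falls.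

The compounds shown carry only piperidin-1-yl and dimethylamino at this place. On these data alone, how a pyrrolidine, a morpholine or a primary amine there would compare on either core remains open.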